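Methyl on the Ring: Compound 4 in Cytotoxicity

The source may hold more compounds than are shown below. What is called first, only, known or untested is meant among the compounds shown, and "the series" means these compounds.

Three compounds sharing one core were measured in a functional assay on HeLa cells (Homo sapiens) for cytotoxicity, read by MTT assay, with a stated time of 72 h, tested at 3 uM; on this read-out higher numbers stand for more inhibition of growth at the one concentration tested and lower numbers for less inhibition of growth. Compound 1 `N/C(=N\NC(=S)N1CCCCCC1)c1ccccn1` gives 36.6% in this assay. Compound 3 `N/C(=N\NC(=S)N1CCSCC1)c1ccccn1` gives 39.7%, and compound 2 `Cc1ccnc(/C(N)=N/NC(=S)N2CCSCC2)c1` gives 40.4%. Compound 1 and compound 3 carry different cores, and that difference is not broken down here. Compound 3 and compound 2 differ by methyl in place of hydrogen on an aromatic carbon, a change that produced a number 0.7 percentage points higher from compound 3 to compound 2 (within the scatter).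

Compound 4 `Cc1ccnc(/C(N)=N/NC(=S)N2CCCCCC2)c1` has not yet been measured. It differs from compound 1 by methyl in place of hydrogen on an aromatic carbon, the same change, made at the same place, as from compound 3 to compound 2. The step is expected to be a number 0.9 percentage points higher from compound 1 to compound 4 (within the scatter) because the measured step was a number 0.7 percentage points higher from compound 3 to compound 2 (within the scatter). Compound 4 is therefore expected to give 37.5% in this assay, with an estimated range from 27% to 48%.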

Compound 4, percent growth inhibition at one concentration: 41.9%
Compound 4: the middle estimate sits 4.4 percentage points below what was measured, within the range that was stated.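

In this assay, putting methyl in place of hydrogen on the core of compound 1 gave a number 5.3 percentage points higher from compound 1 to compound 4 (within the scatter). Set beside the earlier step, the two results cannot be told apart, so the change carried across these two cores without a measurable difference: the same change on two cores in this assay, a number 0.7 percentage points higher (within the scatter) from compound 3 to compound 2 and a number 5.3 percentage points higher (within the scatter) from compound 1 to compound 4, 4.6 percentage points apart, within the scatter of two such steps. Going by these compounds alone, this shows only that neither step left the scatter at the one concentration tested; it does not show that methyl truly raises growth inhibition on either core, or that the two steps are equal.

The compounds shown leave open whether a different group at the same place opposite the ring nitrogen, such as an amine, a methoxy or a longer chain, would give a step beyond the scatter. They also leave open how methyl would behave on any core other than these two.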